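The compounds below may be only part of what the source reports. "The series", "measured", "known", "first", "only" and "open" are said of these compounds alone.

Measured in a functional assay on the whole organism (stomach) with Rattus norvegicus as the target; on this read-out higher numbers stand for an effect only at larger amounts of compound and lower numbers for an effect already at smaller amounts:
- Compound 1 `O=C(O)c1cc(NC(=O)c2ccc([N+](=O)[O-])cc2)cc(C(=O)O)c1`: 61.1 mg/kg
- Compound 2 `CCCc1ccc(C(=O)Nc2cc(C(=O)O)cc(C(=O)O)c2)cc1`: 94.2 mg/kg
- Compound 3 `CCCOc1ccc(C(=O)Nc2cc(C(=O)O)cc(C(=O)O)c2)cc1`: 78 mg/kg

Compound 3 holds the second highest of the three numbers, and both its neighbours lie within the scatter of it: a 1.3-fold higher number from compound 1 to compound 3 (0.11 log units; within the scatter) and a 1.2-fold lower number from compound 2 to compound 3 (0.08 log units; within the scatter). Compound 4 `O=C(O)c1cc(NC(=O)c2ccc(Cl)cc2)cc(C(=O)O)c1` differs from compound 3 by a single exchange on an aromatic carbon: chloro in place of propoxy on an aromatic carbon. Among the compounds with values here, no measured step introduces chloro, so the bearing ones are those that swap a group on an aromatic carbon of the shared core, namely a 1.5-fold higher number from compound 1 to compound 2 (0.19 log units; within the scatter), a 1.3-fold higher number from compound 1 to compound 3 (0.11 log units; within the scatter) and a 1.2-fold lower number from compound 2 to compound 3 (0.08 log units; within the scatter), all within the scatter. A step of similar size, none beyond the scatter, is therefore expected for compound 4 in this assay: a 1.1-fold lower number from compound 3 to compound 4 (0.05 log units; within the scatter). Compound 4 is estimated at 70 mg/kg, in the range 35 mg/kg to 140 mg/kg.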

Compound 4, dose for 50% inhibition: 97.3 mg/kg
For compound 4 the middle estimate is 1.4-fold (0.14 log units) below the measured one, and the stated range covers the measured number.
By their numbers in this assay, from the lowest: compounds 1, 3, 2 and 4 (each within the scatter of the next).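

Chloro brings a single heavy atom to this aromatic carbon, where propoxy has four, yet in this assay the exchange stays within the scatter (a 1.2-fold higher number from compound 3 to compound 4 (0.10 log units; within the scatter)). The same holds against the other two groups (a 1.0-fold higher number from compound 2 to compound 4 (0.01 log units; within the scatter); a 1.6-fold higher number from compound 1 to compound 4 (0.20 log units; within the scatter)). All four groups at this position thus give numbers within the scatter of the next, and no measurement shown offers a reason for this. As far as these compounds go, what an amine, a carboxylic acid or a longer chain would do on this carbon remains open, as does whether any group here can move the number beyond the scatter.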